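Tetrazole for carboxamide: an expected drop from the ceiling

A few compounds are considered here, and "the series" means these few. Any claim that something is new, unique, unknown or untested is made for them only; others in the source may bear on it.

Measured compounds:
compound 1, `C[C@H](Oc1ccc2ncc(/C=C/C(N)=O)c(C3CC3)c2c1)c1c(Cl)ccc(F)c1Cl`, > 5.5
compound 2, `C[C@H](Oc1cc(CO)c2ncc(/C=C/C(=O)O)c(C3CC3)c2c1)c1c(Cl)ccc(F)c1Cl`, 2.9
compound 3, `C[C@H](Oc1nccc(N(c2nc(C(=O)O)cs2)C2CC2)n1)c1c(Cl)ccc(F)c1Cl`, 2.6

This account follows a single change within a small set. In a physicochemical assay for lipophilicity, using the shake flask method (a lower number here means a more polar compound, a higher number a more lipophilic compound), compound 1 gives > 5.5, which is a limit of the assay and not a number. Compound 1 therefore stands at the top of the set, (the limit of > 5.5 in this assay, at which 1 of the 3 values shown sits), while compound 2 gives 2.9 and compound 3 gives 2.6 in this assay.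

Compound 4, `C[C@H](Oc1ccc2ncc(/C=C/c3nn[nH]n3)c(C3CC3)c2c1)c1c(Cl)ccc(F)c1Cl`, has not yet been measured. It differs from compound 1 in one place: 2H-tetrazol-5-yl in place of carbamoyl on a double-bonded chain carbon bound to a double-bonded chain carbon. The author expects a large step in this assay, downward, well beyond the scatter, because compound 2 with its 2.9 and compound 3 with its 2.6 sit far below compound 1. For compound 4 the estimate is 3.8, with a range from 3 to 4.6. The estimated step from compound 1 to compound 4 is thus a number at least 1.70 log units lower from compound 1 to compound 4 (beyond the scatter).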

Compound 4, distribution coefficient: 3.7
Beside the measured number, compound 4's estimate is 0.10 log units above it, and the stated range covers the measured number.
By their numbers in this assay, from the lowest: compounds 3 and 2 (each within the scatter of the next); then compound 4. At a limit, above all of these: compound 1.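

In this assay, for the compounds shown here, the exchange of carbamoyl for 2H-tetrazol-5-yl on a double-bonded chain carbon bound to a double-bonded chain carbon gives a number at least 1.80 log units lower from compound 1 to compound 4 (beyond the scatter), the only single-place comparison in this set. The earlier compounds shown here differ from one another in more than one place, so they could not show that this one change alone moves the value by so much. Compound 1 remains at a limit of the assay and not a number, so only the minimum size of the step is known: the limit of > 5.5 in this assay, at which 1 of the 4 values shown sits.

The compounds shown leave open how this position would respond to a nitrile or a methyl ester in place of carbamoyl. They also leave open whether the same exchange would give a step of similar size on a different core.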